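Furan attachment point on the shared core

This account rests on a few compounds, and the source may have more. Where it says the series, first, only, none or still open, it means among the compounds named here.

For the measured compounds named here, compound 1 `Clc1ccc(-c2cc(-c3ccoc3)cc(-c3cccs3)n2)cc1` is the only member of the series with a number in a functional assay on HCT-15 cells (Homo sapiens) for cytotoxicity, in the presence of a further agent that is not named here; a higher number here means a weaker inhibitor, a lower number a stronger inhibitor: compound 1 gives 50000 nM. Compound 2 `Clc1ccc(-c2cc(-c3ccoc3)cc(-c3ccsc3)n2)cc1` does not reach a number; in this assay compound 2 is reported as > 100000 nM, which is a limit of the assay, as the limit of > 100000 nM in this assay, at which 1 of the 2 values shown sits, records. Going by the values given here, the one measured step, an at least 2.0-fold higher number from compound 1 to compound 2 (0.30 log units; that floor lies within the scatter), is thus known only by its floor, and that floor lies within the scatter, so its true size is open.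

Compound 3 `Clc1ccc(-c2cc(-c3ccco3)cc(-c3cccs3)n2)cc1` is not yet measured. It differs from compound 1 by furan-2-yl in place of furan-3-yl on an aromatic carbon. The measured step went from thiophen-2-yl to thiophen-3-yl and at least weakened the compound; the change to compound 3 runs the other way, from furan-3-yl to furan-2-yl, on the other five-membered ring of the core of compound 1. Among the compounds with values here, that single step is the only guide, and it points, weakly, towards a lower number. The expected step of a 1.7-fold lower number from compound 1 to compound 3 (0.22 log units; within the scatter) is of about the size that the measured step gave as a floor. For compound 3 a value of 30000 nM is estimated, with a range from 10000 nM to 100000 nM.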

Compound 3, half-maximal inhibitory concentration: > 100000 nM
Compound 3 ended at the assay's limit (the forecaster's own chance of this, stated with the estimate: 20%); at least 3.3-fold (0.52 log units) between middle value and limit.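

In this assay, moving only the attachment point of the furan on the shared core, with the atoms unchanged, gives an at least 2.0-fold higher number from compound 1 to compound 3 (0.30 log units; that floor lies within the scatter), so the position opposite the ring nitrogen now has a reading of its own alongside the earlier thiophene change. Compound 3 is reported as > 100000 nM, which is a limit of the assay. Compound 1 therefore remains the only compound in this set with a number, and neither change away from its furan-3-yl and thiophen-2-yl arrangement has produced a lower one, though the new step is known only by its floor because it ends at a limit, like the earlier one: the limit of > 100000 nM in this assay, at which 2 of the 3 values shown sit.

As far as these compounds go, the true size of the change from furan-3-yl to furan-2-yl stays open, and with it whether the attachment point of the furan matters at all in this assay, since the floor alone cannot separate the two compounds. Also open, from the compounds shown here alone, is whether an amine or a carboxylic acid, in place of either five-membered ring on the shared core, would bring the series to numbers well inside the range of this assay.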